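The source may hold more compounds than are shown below. What is called first, only, known or untested is meant among the compounds shown, and "the series" means these compounds.

Among the three measured compounds, compound 3 `Cc1cccc(Oc2nc3cc(O[C@H]4CC[C@@H](C(=O)O)CC4)ccc3n2C)c1` stands highest in an assay on isolated protein for inhibition of Long-chain-fatty-acid--CoA ligase 1 (Mus musculus), read by mass spectrometry, with a stated time of 90 min, in the presence of a further agent that is not named here (a higher number here means a weaker inhibitor, a lower number a stronger inhibitor), where compound 3 gives 21000 nM. Compound 1 `Cc1ccc(Cc2nc3cc(O[C@H]4CC[C@@H](C(=O)O)CC4)ccc3n2C)cc1` gives 80 nM in this assay, and compound 2 `Cn1c(Cc2ccc3c(c2)OCC3)nc2cc(O[C@H]3CC[C@@H](C(=O)O)CC3)ccc21` gives 36 nM, so that a 2.2-fold lower number from compound 1 to compound 2 (0.35 log units; beyond the scatter). The steps that lead to compound 3 are large: a 260-fold higher number from compound 1 to compound 3 (2.42 log units; beyond the scatter), and a 580-fold higher number from compound 2 to compound 3 (2.77 log units; beyond the scatter).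

Compound 4 `Cc1cccc(COc2nc3cc(O[C@H]4CC[C@@H](C(=O)O)CC4)ccc3n2C)c1` differs from compound 3 by 3-methylbenzyl in place of 3-methylphenyl on an oxygen on an aromatic ring. This reintroduces a saturated chain carbon between the aromatic ring and the core, as in compound 1 and compound 2, while keeping the oxygen of compound 3 in place. Among the compounds with values here, no measured pair shows this exact combination. The step from compound 1 to compound 3 bears most directly on it, since it removed the chain carbon and inserted the oxygen in a single move and cost a large amount of potency; compound 2 to compound 3 points the same way. Because of a 260-fold higher number from compound 1 to compound 3 (2.42 log units; beyond the scatter), a substantial lower number is expected for compound 4, though the longer link to the core leaves uncertainty, so only part of that recovery is estimated. The expected step is a 14-fold lower number from compound 3 to compound 4 (1.15 log units; beyond the scatter), and compound 4 is estimated at 1500 nM, with a range from 150 nM to 15000 nM.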

Compound 4, half-maximal inhibitory concentration: 8100 nM
For compound 4 the middle estimate is 5.4-fold (0.73 log units) below the measured one, and the stated range covers the measured number.
By their numbers in this assay, from the lowest: compound 2; then compound 1; then compound 4; then compound 3.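

In this assay, the extra chain carbon of 3-methylbenzyl on the oxygen on an aromatic ring buys back only a small part of the loss seen in compound 3 (a 2.6-fold lower number from compound 3 to compound 4 (0.41 log units; beyond the scatter)). Compound 4 has that chain carbon and still lies far from the two compounds with no oxygen in the link (a 100-fold higher number from compound 1 to compound 4 (2.01 log units; beyond the scatter); a 230-fold higher number from compound 2 to compound 4 (2.35 log units; beyond the scatter)), so the missing chain carbon alone does not account for the weak number of compound 3. Among these four compounds, both with the oxygen link give the two highest numbers, although the step from compound 1 to compound 4 also moves the methyl from the 4-methylbenzyl to the 3-methylbenzyl arrangement, so it does not isolate the oxygen. Nothing measured here gives a reason for the size of these steps.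

The compounds shown leave open how much of the gap belongs to the oxygen and how much to the place of the methyl, which a 3-methylbenzyl group directly on the aromatic carbon of the core would help to separate. Within the data shown here, they also leave open whether an amine or a two-carbon chain as the link would behave like the oxygen link or like the single chain carbon of compound 1.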